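Cyanoguanidine chain series: ethyl to methyl at the imine

The source may report more compounds than this note shows. Statements on the series, on what has been measured and on what is new or still open speak of the compounds shown alone.

For the measured compounds named here, compound 2 `CC/N=C(/NC#N)NCCCCn1nc(-c2ccccc2)c(C)cc1=O` stands highest of the two numbers in a functional assay on the whole organism with Rattus norvegicus as the target, at a dose of 100 mg/kg (on this read-out lower numbers stand for less inhibition and higher numbers for more inhibition at the one dose given (going by the name of the read-out)), where compound 2 gives 38.8% and compound 1 `C/N=C(/NC#N)NCCCCCn1nc(-c2ccccc2)c(C)cc1=O` gives 28.5%; the one step, a number 10.3 percentage points higher from compound 1 to compound 2 (beyond the scatter), concerns a different part of the molecule. Going by the values given here, compound 3 `C/N=C(/NC#N)NCCCCn1nc(-c2ccccc2)c(C)cc1=O` carries the change (hydrogen in place of methyl on a saturated chain carbon bound to a double-bonded nitrogen), which no measured step bears on. With no guidance on this position, the expected step in this assay is a number 6.8 percentage points lower from compound 2 to compound 3 (within the scatter), within the scatter and leaning slightly downward only as a cautious guess. Compound 3 is therefore estimated at 32%, between 16% and 48%.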

Compound 3, a percentage reported as inhibition, in the whole organism at one dose (the size of the read-out at that dose, not a potency): 46.4%
Estimate against measurement, compound 3: 14.4 percentage points below; measured number inside the range.
By their numbers in this assay, from the lowest: compound 1; then compounds 2 and 3 (each within the scatter of the next).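

In this assay, ethyl to methyl at this position gives a number 7.6 percentage points higher from compound 2 to compound 3 (within the scatter), so this change on a saturated chain carbon bound to a double-bonded nitrogen does not separate the two compounds. The larger difference is a number 17.9 percentage points higher from compound 1 to compound 3 (beyond the scatter), with the change on a saturated chain carbon, four bonds along the chain from an aromatic nitrogen. No available evidence accounts for either step. Open, on these data alone, is whether a longer chain, such as propyl, or a cyclopropyl group at this position would stay within the scatter. Also open, as far as these compounds go, is whether these numbers keep their order at other doses.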